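Phenyl for Methyl on an Aromatic Nitrogen: Two Amide Isomers

The compounds below may be only part of what the source reports. "The series", "measured", "known", "first", "only" and "open" are said of these compounds alone.

Compound 1 `Cn1cc(NC(=O)c2cccc(NS(=O)(=O)c3ccccc3)c2)cn1` and compound 3 `Cn1cc(NC(=O)c2ccc(NS(=O)(=O)c3ccccc3)cc2)cn1` are built from the same atoms joined differently; the difference between their two cores is not broken down here. In a functional assay on A549 cells (Homo sapiens) for inhibition, read by MTT assay, with a stated time of 48 h (a higher number here means a weaker inhibitor, a lower number a stronger inhibitor), compound 1 reaches only the limit of the assay, > 100000 nM. Compound 3 likewise gives in this assay only a limit, > 100000 nM. Compound 2 `O=C(Nc1cnn(-c2ccccc2)c1)c1cccc(NS(=O)(=O)c2ccccc2)c1` differs from compound 1 by phenyl in place of methyl on an aromatic nitrogen, and in this assay compound 2 gives 26800 nM, a step of an at least 3.7-fold lower number from compound 1 to compound 2 (0.57 log units; beyond the scatter). That step is known only as a bound because of the limit of > 100000 nM in this assay, at which 2 of the 3 values shown sit. Compound 4 `O=C(Nc1cnn(-c2ccccc2)c1)c1ccc(NS(=O)(=O)c2ccccc2)cc1` differs from compound 3 by the same change, (phenyl in place of methyl on an aromatic nitrogen). Taking the measured step from compound 1 to compound 2 as the guide, the step from compound 3 to compound 4 is expected to be an at least 3.3-fold lower number from compound 3 to compound 4 (0.52 log units; beyond the scatter). Compound 4 is therefore estimated at 30000 nM, within an expected range from 8000 nM to 100000 nM.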

Compound 4, half-maximal inhibitory concentration: 87100 nM
The estimate for compound 4 lay 2.9-fold (0.46 log units) below the measured number; low and high end bracket the measured number.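

In this assay, the same change on the core of compound 3 gives an at least 1.1-fold lower number from compound 3 to compound 4 (0.05 log units; that floor lies within the scatter), so the result does not run against the step on the first core, but this step alone is not shown to exceed the scatter. The data do not show that the change carries over with the same size, or with a different one: the same change on two cores in this assay, an at least 3.7-fold lower number (0.57 log units; beyond the scatter) from compound 1 to compound 2 and an at least 1.1-fold lower number (0.05 log units; that floor lies within the scatter) from compound 3 to compound 4; the limit leaves it open whether they differ. Both steps remain bounds and not measured sizes because of the assay limit: the limit of > 100000 nM in this assay, at which 2 of the 4 values shown sit.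

From the compounds shown here alone, the true size of each step stays open, as does whether the change would have any effect on a third core. Also open, going by these compounds, is how a benzyl group or a longer alkyl chain on the same aromatic nitrogen would compare with phenyl and methyl.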